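Nitrooxy ester series: lipophilicity notes ahead of compound 4

The source may report more compounds than this note shows. Statements on the series, on what has been measured and on what is new or still open speak of the compounds shown alone.

Three measured members share the same core. Compound 1 `O=C(CCCO[N+](=O)[O-])Oc1ccccc1C(=O)O`, compound 2 `O=C(CCCCC(CO[N+](=O)[O-])O[N+](=O)[O-])Oc1ccccc1C(=O)O` and compound 3 `O=C(CCO[N+](=O)[O-])Oc1ccccc1C(=O)O` have each been run in a physicochemical assay for lipophilicity; a higher number here means a more lipophilic compound, a lower number a more polar compound: compound 1 gives 1.6, compound 2 gives 1.6 and compound 3 gives 1.6. Among the compounds with values here, the single one-place step so far, no change at the digits printed from compound 1 to compound 3 (within the scatter), lies within the scatter. Within the data shown here, compound 3 therefore stands level with compound 1 and compound 2 at the digits printed; no compound in the set is separated from another beyond the scatter.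

Compound 4 `O=C(CC(CO[N+](=O)[O-])O[N+](=O)[O-])Oc1ccccc1C(=O)O` differs from compound 3 in one place: (nitrooxy)methyl in place of hydrogen on a saturated chain carbon bound to an oxygen on an unsaturated carbon and a saturated chain carbon. Among the measured compounds shown here, no measured step adds a (nitrooxy)methyl group to a hydrogen-bearing chain carbon, so the closest guide is indirect. Compound 2 carries two nitrooxy groups on a longer chain and gives the same value as compound 1 with one nitrooxy group; the step from compound 1 to compound 3 likewise left the number unchanged. From this, compound 4 is expected to show a step of no change at the digits printed from compound 3 to compound 4 (within the scatter) of no size beyond the scatter. Compound 4 is therefore estimated at 1.6, with a range from 1.3 to 1.9.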

Compound 4, partition coefficient: 1.6
The estimate for compound 4 equals the measured number at the digits printed; the measured number falls inside the stated range.
By their numbers in this assay, from the lowest: compounds 1, 2, 3 and 4 (each within the scatter of the next).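

In this assay the series now has a direct reading for (nitrooxy)methyl in place of hydrogen on a saturated chain carbon bound to an oxygen on an unsaturated carbon and a saturated chain carbon: no change at the digits printed from compound 3 to compound 4 (within the scatter). The earlier compounds shown here gave no step of this kind, and a second reading now comes from another place, nitrooxy in place of hydrogen on a saturated chain carbon bound to two saturated chain carbons, with no change at the digits printed from compound 1 to compound 4 (within the scatter), so neither of these two additions separates the compounds at the digits printed. No supporting evidence is available to explain these readings.

The compounds shown leave open whether an amine or a methyl group in place of hydrogen on the same saturated chain carbon would also read level with compound 3 in this assay. Within the data shown here, they also leave open whether a third nitrooxy group on the chain would give a step beyond the scatter in this assay, since every compound here carries only one or two such groups.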